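The compounds below may be only part of what the source reports. "The series", "measured", "known", "first", "only" and "open" are said of these compounds alone.

Of the compounds shown here, two have so far been tested in a functional assay on NCI-H520 cells (Homo sapiens) for inhibition, read by MTT assay, with a stated time of 48 h, tested at 10 uM; on this read-out higher numbers stand for more inhibition at the one concentration tested (going by the name of the read-out) and lower numbers for less inhibition. Compound 1 `CCc1ccc(Nc2cc(NC(=O)Nc3c(Cl)cccc3Cl)ncn2)cc1` gives 31.5% in this assay. For the measured compounds named here, compound 2 `COc1cc(NC(=O)Nc2cc(Nc3ccc(C)c(F)c3)ncn2)cc(OC)c1` gives 30.6% in this assay, a value that sits within the usual scatter of the one for compound 1, so on this read-out the two compounds cannot be told apart, and neither can be called the weaker or the stronger. Compound 3 `COc1cc(NC(=O)Nc2cc(Nc3cc(I)ccc3OC)ncn2)cc(OC)c1` has not yet been measured. It differs from compound 2 in one place: 5-iodo-2-methoxyphenyl in place of 3-fluoro-4-methylphenyl on a nitrogen on an aromatic ring. Going by the values given here, no measured pair shows what such a change does, so there is no basis for expecting a shift in either direction in this assay. The expected change, a number 0.6 percentage points lower from compound 2 to compound 3 (within the scatter) in this assay, is small and not beyond the scatter. In this assay compound 3 is estimated to give 30%, with a likely range from 15% to 45%.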

Compound 3, a percentage reported as inhibition, at one concentration (the size of the read-out at that concentration, not a potency): 55%
For compound 3 the middle estimate is 25 percentage points below the measured one, and the stated range ends below it.
By their numbers in this assay, from the lowest: compounds 2 and 1 (each within the scatter of the next); then compound 3.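

Changing the group on this nitrogen moves the result in this assay by a number 24.4 percentage points higher from compound 2 to compound 3 (beyond the scatter) and so gives the first difference in this set that stands clear of the scatter. This position is therefore not indifferent to what it carries, at least for this pair of groups. However, the change replaces a whole substituted ring, so this single step cannot separate the contribution of the iodine from that of the methoxy group or the loss of the fluorine and methyl groups, and nothing available explains the gain.

Still open, from the compounds shown here alone, is whether the iodo or the methoxy group alone would produce this step, and whether an amine or a carboxylic acid on the same ring would raise or lower the number. It is also unknown whether the same swap would have a similar effect in compound 1, which carries a different group on the urea.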